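Swapping a thiophene ring for phenyl on a shared pyridine-free core

The compounds below may be only part of what the source reports. "The series", "measured", "known", "first", "only" and "open" are said of these compounds alone.

Measured compounds in an assay on isolated protein for inhibition of DNA topoisomerase 1 (Homo sapiens), with a stated time of 30 min, tested at 100 uM; a higher number here means a stronger effect of the compound at the concentration tested, a lower number a weaker effect:
- compound 1 `Oc1cccc(-c2cc(-c3ccc(Cl)cc3)nc(-c3cccs3)c2)c1` gives 15.1%
- compound 2 `Oc1cccc(-c2cc(-c3cccs3)nc(-c3ccccc3Cl)c2)c1` gives 2.7%
- compound 3 `Oc1cccc(-c2cc(-c3cccc(Cl)c3)nc(-c3cccs3)c2)c1` gives 7.6%

Compound 2 has the lowest of the three numbers. Its nearest neighbour is compound 3, reached by a number 4.9 percentage points higher from compound 2 to compound 3 (within the scatter); the furthest is compound 1, and the step of a number 12.4 percentage points lower from compound 1 to compound 2 (beyond the scatter) is the only one here that rises above the scatter. Compound 4 `Oc1cccc(-c2cc(-c3ccccc3)nc(-c3ccccc3Cl)c2)c1` has not yet been measured. It differs from compound 2 by phenyl in place of thiophen-2-yl on an aromatic carbon.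

Among the compounds with values here, none of the measured steps touches this position: all three of them, a number 12.4 percentage points lower from compound 1 to compound 2 (beyond the scatter), a number 7.5 percentage points lower from compound 1 to compound 3 (within the scatter) and a number 4.9 percentage points higher from compound 2 to compound 3 (within the scatter), move the chlorine around the chlorophenyl ring while the thiophen-2-yl group stays in place. Within the data shown here, there is therefore nothing among the measured compounds that shows which way a phenyl-for-thiophene exchange pulls the number in this assay. With compound 2 already near the bottom of the range and no guidance from the data, the expected step is a number 3.3 percentage points higher from compound 2 to compound 4 (within the scatter), within the scatter. Compound 4 is estimated at 6%, most likely between 0% and 20%.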

Compound 4, a percentage reported as inhibition, at one concentration (the size of the read-out at that concentration, not a potency): 3.2%
Compound 4: middle estimate off by 2.8 percentage points, on the high side; the measured number falls inside the stated range.
By their numbers in this assay, from the lowest: compounds 2, 4, 3 and 1 (each within the scatter of the next, the first and the last beyond it).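

In this assay, the exchange at this aromatic carbon next to the ring nitrogen gives a number 0.5 percentage points higher from compound 2 to compound 4 (within the scatter), so with the 2-chlorophenyl group in place, thiophen-2-yl and phenyl cannot be told apart here. Compound 2 gives 2.7% and compound 4 gives 3.2% at the single concentration tested, both small read-outs, which leaves little room for a further loss to appear. Nothing measured here offers an explanation for this result.

Still open, going by these compounds, is whether the same exchange would also leave the number unmoved with the 4-chlorophenyl group of compound 1, which gives 15.1% with thiophen-2-yl at this position. The compounds shown also leave open how an amine or a carboxylic acid on the phenyl ring would read in this assay at this position.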